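Hydroxy for chloro on a thiosemicarbazone anilide

This account rests on a few compounds, and the source may have more. Where it says the series, first, only, none or still open, it means among the compounds named here.

Compound 1 `Oc1ccc(/C=N/NC(=S)Nc2ccccc2Cl)cc1`: 46800 nM
Compound 2 `Cc1cccc(NC(=S)N/N=C/c2ccc(O)cc2)c1`: 30400 nM

Of the compounds shown here, two have been measured in an assay for inhibition of ribonucleoside-diphosphate reductase RR1 (Homo sapiens), with a stated time of 30 min; on this read-out lower numbers stand for stronger inhibition and higher numbers for weaker inhibition. Compound 1 gives 46800 nM, the highest of the two numbers, while compound 2 gives 30400 nM; the gap between them lies within the scatter, so the two cannot be told apart. Among the compounds with values here, no pair that differs in a single place has been measured.

Compound 3 `Oc1ccc(/C=N/NC(=S)Nc2ccccc2O)cc1` is the one still to be measured. It differs from compound 1 by hydroxy in place of chloro on an aromatic carbon. Within the data shown here, with no measured step of this kind to lean on, he expects the change to move the number little, if at all, beyond the scatter, with no firm direction.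

He estimates for compound 3 in this assay a value of 40000 nM, between 15000 nM and 110000 nM, which corresponds to a step of a 1.2-fold lower number from compound 1 to compound 3 (0.07 log units; within the scatter).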

Compound 3, half-maximal inhibitory concentration: 29300 nM
Estimate against measurement, compound 3: 1.4-fold (0.14 log units) above; the measured number falls inside the stated range.
By their numbers in this assay, from the lowest: compounds 3, 2 and 1 (each within the scatter of the next).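

In this assay, hydroxy in place of chloro on an aromatic carbon ortho to a large group gives a 1.6-fold lower number from compound 1 to compound 3 (0.20 log units; within the scatter) and so does not separate the two compounds. Within the data shown here, this is the first measured single-place step in the set, and it shows that this position can take a group with one hydrogen-bond donor and one hydrogen-bond acceptor in place of chloro, which has neither, without a shift beyond the scatter. The data give no measured reason for this result.

On these data alone, whether an amine, a methoxy group or a carboxylic acid at this position would shift the number beyond the scatter remains open. So does whether the same exchange would have as small an effect at another place on this ring.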